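Swapping a methyl for an ethynyl on the amide-side ring

A few compounds are considered here, and "the series" means these few. Any claim that something is new, unique, unknown or untested is made for them only; others in the source may bear on it.

Measured compounds:
- compound 1, `COc1ccccc1NC(=O)CCc1nc(Cc2ccc(NC(C)=O)cc2)no1`: 87.7%
- compound 2, `CC(=O)Nc1ccc(Cc2noc(CCC(=O)Nc3cccc(C)c3)n2)cc1`: 16.4%

Both compounds share one core and differ only in the ring attached to the amide-type nitrogen. In a functional assay on the whole organism (strain C57BL/6) for inhibition, with Mus musculus as the target, read by paw edema, with stated times of 1 h and 4 h, at a dose of 100 mg/kg by the oral route (on this read-out lower numbers stand for less inhibition and higher numbers for more inhibition at the one dose given (going by the name of the read-out)), compound 1 gives 87.7%, while compound 2 gives 16.4%, the lowest of the two numbers. Among the compounds with values here, the one measured step, a number 71.3 percentage points lower from compound 1 to compound 2 (beyond the scatter), came with 3-methylphenyl in place of 2-methoxyphenyl on an amide-type nitrogen.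

Within the data shown here, compound 3, `C#Cc1cccc(NC(=O)CCc2nc(Cc3ccc(NC(C)=O)cc3)no2)c1`, keeps the core of compound 2 and changes only one group: ethynyl in place of methyl on an aromatic carbon. The change sits on an aromatic carbon of a six-membered aromatic ring of carbon only, meta to a large group.

Among the measured compounds shown here, no measured step bears on this change. For the measured compounds named here, the single step from compound 1 to compound 2 concerns a different ring substitution, so it gives no direction for an exchange of methyl for ethynyl. With nothing to lean on, the expectation is a step that stays within the scatter. Compound 3 is therefore estimated at 20%, in the range 0% to 50%, which means an expected step of a number 3.6 percentage points higher from compound 2 to compound 3 (within the scatter) in this assay.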

Compound 3, a percentage reported as inhibition, in the whole organism at one dose (the size of the read-out at that dose, not a potency): 84.9%
For compound 3 the middle estimate is 64.9 percentage points below the measured one, outside the stated range (above it).
By their numbers in this assay, from the lowest: compound 2; then compounds 3 and 1 (each within the scatter of the next).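

In this assay this position proves highly sensitive: ethynyl in place of methyl gives a number 68.5 percentage points higher from compound 2 to compound 3 (beyond the scatter) even though the change only takes a group of 1 heavy atom to one of 2 heavy atoms on the same aromatic carbon. The comparison with the other ring gives a number 2.8 percentage points lower from compound 1 to compound 3 (within the scatter) for 3-ethynylphenyl in place of 2-methoxyphenyl, so these two rings on the amide-type nitrogen cannot be told apart in this read-out. The low number of compound 2 therefore does not come from the shared core alone, nor from every group meta to a large group, and the data given offer no explanation for the gap between methyl and ethynyl.

The compounds shown leave open whether the high number needs the triple bond of ethynyl or would also appear with a nitrile, a chlorine, an amine or a longer chain such as propynyl at this same place. On these data alone, it also remains open whether compound 2 and compound 3 would stay this far apart at other oral doses.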